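Acetylation of a Phenol in a Cytotoxicity Screen

The source may hold more compounds than are shown below. What is called first, only, known or untested is meant among the compounds shown, and "the series" means these compounds.

Compound 1 `O=C(Nc1ncc([N+](=O)[O-])s1)c1cc(Cl)cc(Cl)c1O` in this assay: 100%
Compound 2 `CC(=O)Oc1c(Cl)cc(Cl)cc1C(=O)Nc1ncc([N+](=O)[O-])s1` in this assay: 100%
Compound 3 `COc1ccc(O)c(C(=O)Nc2ncc([N+](=O)[O-])s2)c1` in this assay: 100%

Of the compounds shown here, three have been measured in an ADME assay on HEK-293T cells (Homo sapiens) for cytotoxicity, read by MTT assay, tested at 25 uM; on this read-out higher numbers stand for a weaker effect at the one concentration tested and lower numbers for a stronger effect. Compound 1 gives 100%, compound 2 gives 100%, and compound 3 gives 100%. Compound 3 stands level with both at the digits reported.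

Compound 2 arises from compound 1 by acetyl in place of hydrogen on an oxygen on an aromatic ring. The step it made in this assay is no change at the digits printed from compound 1 to compound 2 (within the scatter). The difference between the core of compound 1 and the core of compound 3 is not broken down here.

Compound 4 `COc1ccc(OC(C)=O)c(C(=O)Nc2ncc([N+](=O)[O-])s2)c1` has not yet been measured. It arises from compound 3 by acetyl in place of hydrogen on an oxygen on an aromatic ring, the same change as from compound 1 to compound 2, at the same kind of place.

Because no change at the digits printed from compound 1 to compound 2 (within the scatter) left the read-out where it was, and because compound 3 gives 100%, the step is expected to be no change at the digits printed from compound 3 to compound 4 (within the scatter). Compound 4 is therefore estimated at 100% in this assay, with a range from 90% to 100%.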

Compound 4, a percentage reported as activity, at one concentration (the size of the read-out at that concentration, not a potency): 100%
For compound 4 middle estimate and measured number coincide at the digits printed; measured number inside the range.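

In this assay, the change from hydroxy to acetoxy gave no change at the digits printed from compound 3 to compound 4 (within the scatter), and on the two cores it behaved alike: the same change on two cores in this assay, no change at the digits printed (within the scatter) from compound 1 to compound 2 and no change at the digits printed (within the scatter) from compound 3 to compound 4, 0 percentage points apart, within the scatter of two such steps

So, within these four compounds, the step carried from the core of compound 1 to the core of compound 3 without any visible difference. Going by these compounds alone, this agreement is a narrow one, however, as all four compounds share the same printed value and neither step moved the read-out, so the pair shows only that the change stayed silent twice, not that a step of real size would transfer unchanged. Nor does it show how the change would behave on a core that has a stronger effect at the one concentration tested.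

The compounds shown leave open whether a longer acyl chain in place of acetyl, or an amine or a carboxylic acid on the same oxygen-bearing ring, would shift this read-out at all. They also leave open whether the hydroxy-to-acetoxy change would stay silent on cores other than these two.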